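Salicylanilide series on KG-1 cells: benzyl replaced by bromo

This account rests on a few compounds, and the source may have more. Where it says the series, first, only, none or still open, it means among the compounds named here.

Measured compounds:
compound 1 `O=C(Nc1cc(F)cc(F)c1)c1ccc2cccnc2c1O`: 3340 nM
compound 2 `N#Cc1ccc(NC(=O)c2cc(Cc3ccccc3)ccc2O)cc1`: 1930 nM

In a functional assay on KG-1 cells (Homo sapiens) for cytotoxicity, read by luminescence and CellTiter-Glo, with a stated time of 3 days (on this read-out higher numbers stand for weaker inhibition and lower numbers for stronger inhibition), compound 2 gives 1930 nM, the lowest number of the two measured, though compound 1 with 3340 nM sits within the scatter of it, so no order between them is claimed. Compound 3 `N#Cc1ccc(NC(=O)c2cc(Br)ccc2O)cc1` awaits measurement; it differs from compound 2 by bromo in place of benzyl on an aromatic carbon. Going by the values given here, no pair of measured compounds differing in a single place exists in this set, so the change has no precedent here. A modest step toward a higher number is expected, a 1.8-fold higher number from compound 2 to compound 3 (0.26 log units; within the scatter). Compound 3 is estimated at 3500 nM, with a range from 1200 nM to 10000 nM.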

Compound 3, half-maximal inhibitory concentration: 1290 nM
Compound 3: the middle estimate sits 2.7-fold (0.43 log units) above what was measured; low and high end bracket the measured number.
By their numbers in this assay, from the lowest: compounds 3, 2 and 1 (each within the scatter of the next, the first and the last beyond it).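

In this assay, going by these compounds alone, bromo in place of benzyl on the aromatic carbon para to a hydroxy group gives a 1.5-fold lower number from compound 2 to compound 3 (0.17 log units; within the scatter) and is the first single-place step. At this position, the number therefore does not depend on keeping the benzyl ring: one bromine atom serves in place of seven carbons with no change beyond the scatter. No available evidence gives a reason for this result.

Open, on these data alone, is whether an amine, a carboxylic acid or a longer chain at this carbon would stay within the scatter. Also open, as far as these compounds go, is whether the same exchange would hold on the core of compound 1.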